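Sulfonamide linker series: switching the aryl group on the sulfonyl sulfur

The compounds below may be only part of what the source reports. "The series", "measured", "known", "first", "only" and "open" are said of these compounds alone.

Measured compounds:
- compound 1, `CCCCc1ccc(S(=O)(=O)NCCCCCCNCc2ccc(Br)cc2)cc1`, 5700 nM
- compound 2, `O=S(=O)(NCCCCCCNCc1ccc(Br)cc1)c1c(Cl)cccc1Cl`, 14700 nM

In a functional assay on MIA PaCa-2 cells (Homo sapiens) for inhibition, read by MTT assay, with a stated time of 72 h (a higher number here means a weaker inhibitor of growth, a lower number a stronger inhibitor of growth), compound 1 gives 5700 nM, while compound 2 gives 14700 nM. Compound 2 thus stands highest of the two numbers; compound 1 is its nearest neighbour, and the gap between them lies beyond the usual scatter of this assay.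

Compound 3 is `CC(C)c1ccc(S(=O)(=O)NCCCCCCNCc2ccc(Br)cc2)cc1`. It differs from compound 2 by 4-isopropylphenyl in place of 2,6-dichlorophenyl on a sulfonyl sulfur. Going by the values given here, no step between two measured compounds matches this change, so its effect is estimated from what the two values show. Because compound 1, which also carries an alkyl-substituted phenyl on the sulfonyl sulfur, gives 5700 nM, compound 3 is expected to land near that figure, a downward step that is estimated at a 2.5-fold lower number from compound 2 to compound 3 (0.39 log units; beyond the scatter). Compound 3 is therefore expected to give 6000 nM in this assay, within a range of 2500 nM to 15000 nM.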

Compound 3, concentration for 50% growth inhibition: 5730 nM
Beside the measured number, compound 3's estimate is 1.0-fold (0.02 log units) above it; the measured number falls inside the stated range.
By their numbers in this assay, from the lowest: compounds 1 and 3 (each within the scatter of the next); then compound 2.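

In this assay, going by these compounds alone, putting 4-isopropylphenyl in place of 2,6-dichlorophenyl on the sulfonyl sulfur gives a 2.6-fold lower number from compound 2 to compound 3 (0.41 log units; beyond the scatter), the first single change at this position to be read as a step, and a modest one. Isopropyl in place of butyl on an aromatic carbon gives a 1.0-fold higher number from compound 1 to compound 3 (0.00 log units; within the scatter), so compound 1 and compound 3 cannot be told apart here, and these two alkyl groups give the same result within the scatter. Nothing available explains either step.

The compounds shown leave open whether an unsubstituted phenyl on the sulfonyl sulfur would fall with compound 2 or with compound 1 and compound 3. They also leave open how an amine, a carboxylic acid or a longer alkyl chain in place of isopropyl would read in this assay.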